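This account rests on a few compounds, and the source may have more. Where it says the series, first, only, none or still open, it means among the compounds named here.

Of the compounds shown here, three of this study have been measured in a functional assay, read by spectrophotometry, with a stated time of 20 min (a lower number here means a stronger inhibitor, a higher number a weaker inhibitor), all of them weak. Compound 1 `CCC(C)C(C(=O)Nc1ccc(C(C)=O)cc1)N(C(=O)c1ccccc1)S(=O)(=O)c1ccc(C)cc1` gives 10000000 nM, compound 2 `CC(=O)c1ccc(NC(=O)C(C(C)C)N(C(=O)c2ccccc2)S(=O)(=O)c2ccc(C)cc2)cc1` gives 12000000 nM, and compound 3 `CC(=O)c1ccc(NC(=O)C2CC(O)CN2S(=O)(=O)c2ccc(C)cc2)cc1` gives 25000000 nM, the highest of the three numbers; its gap to compound 2 is beyond the scatter and its gap to compound 1 wider still. Going by the values given here, the one measured step, a 1.2-fold higher number from compound 1 to compound 2 (0.08 log units; within the scatter), concerns a chain substituent and does not touch the aromatic sulfonyl group.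

Compound 4 `CC(=O)c1ccc(NC(=O)C2CC(O)CN2S(=O)(=O)c2ccc([N+](=O)[O-])cc2)cc1` differs from compound 3 by nitro in place of methyl on an aromatic carbon. Among the compounds with values here, no measured pair shows a change on that ring, so nothing among the known steps speaks for a move in either direction in this assay, and the expectation is a step within the scatter, no change at the digits printed from compound 3 to compound 4 (within the scatter). Compound 4 is therefore estimated at 25000000 nM, with a range from 8000000 nM to 80000000 nM.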

Compound 4, half-maximal inhibitory concentration: 7100000 nM
Beside the measured number, compound 4's estimate is 3.5-fold (0.55 log units) above it, and the stated range ends above it.
By their numbers in this assay, from the lowest: compounds 4, 1 and 2 (each within the scatter of the next); then compound 3.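

In this assay, replacing methyl with nitro gives a 3.5-fold lower number from compound 3 to compound 4 (0.55 log units; beyond the scatter). Going by these compounds alone, this shows that the aromatic carbon para to a large group can affect the reading, which the earlier compounds could not show, as their only measured step concerned a chain substituent and lay within the scatter. No measurement of any property of these two groups accompanies the result, so the step stands as an observation alone.

This single pair leaves open whether the lower number is specific to nitro or would also follow other replacements of methyl, such as an amine, a carboxylic acid or a chlorine atom on the same carbon. It also leaves open whether the 4-methylphenyl to 4-nitrophenyl change would act similarly in compound 1 and compound 2, which carry the same methyl group on a different core.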